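This account rests on a few compounds, and the source may have more. Where it says the series, first, only, none or still open, it means among the compounds named here.

Measured compounds:
compound 1, `CC(=O)OC[C@@H]1CN(C(C)=O)CCN1S(=O)(=O)c1ccc(F)cc1`, 1 mg/kg in a functional assay on the whole organism (strain CD-1) with Mus musculus as the target, with a stated time of 20 min; a higher number here means that more compound is needed for the effect, a lower number that less compound is needed
compound 2, `CCOC(=O)C1CN(C(C)=O)CCN1S(=O)(=O)c1ccc(F)cc1`, 0.1 mg/kg in this assay
compound 3, `CC(=O)OCC1CN(S(=O)(=O)c2ccc(F)cc2)CCN1C(C)=O`, > 10 mg/kg in this assay

Compound 3 stands apart from the other two: its value is a limit of this assay and not a number, so it is only known that compound 3 needed more than the highest dose tested, (the limit of > 10 mg/kg in this assay, at which 1 of the 3 values shown sits). Compound 1 gives 1 mg/kg and compound 2 gives 0.1 mg/kg; these two share the arrangement in which the substituted ring carbon sits next to the sulfonyl-bearing nitrogen, whereas in compound 3 the substituted carbon sits next to the acetyl-bearing nitrogen.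

Compound 4, `CCOC(=O)C1CN(S(=O)(=O)c2ccc(F)cc2)CCN1C(C)=O`, has not yet been measured. It differs from compound 3 in one place: ethoxycarbonyl in place of acetoxymethyl on a saturated ring carbon. The same exchange separates compound 1 from compound 2, and there compound 2 sat at the lower dose; whether the exchange does the same on the other arrangement is not known from the values shown. Because compound 3 sits at a limit, the step of an at least 2.0-fold lower number from compound 3 to compound 4 (0.30 log units; that floor lies within the scatter) that the estimate implies cannot be read as a step of known size. Compound 4 is expected to give about 5 mg/kg, with a range from 1 mg/kg to 30 mg/kg.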

Compound 4, minimum effective dose: 1 mg/kg
Compound 4: middle estimate off by 5.0-fold (0.70 log units), on the high side, and the stated range covers the measured number.
By their numbers in this assay, from the lowest: compound 2; then compounds 1 and 4 (each within the scatter of the next). At a limit, above all of these: compound 3.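

With the saturated ring carbon next to the ring atom that bears an acetyl group, ethoxycarbonyl in place of acetoxymethyl gives an at least 10-fold lower number from compound 3 to compound 4 (1.00 log units; beyond the scatter) in this assay, so this exchange is now seen to matter beyond the scatter at this position, and this arrangement of the shared core can give a measured number and not only a limit. On the other arrangement, compound 1 gives 1 mg/kg and compound 2 gives 0.1 mg/kg, so the printed values of both pairs point the same way, with the ethoxycarbonyl compound at the lower dose. The value of compound 3, > 10 mg/kg, is a limit of the assay and not a number, so the step has a floor but no known full size: the limit of > 10 mg/kg in this assay, at which 1 of the 4 values shown sits.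

The compounds shown do not tell whether the ester at this position is needed, or whether a carboxylic acid, a primary amide or a longer chain such as propoxycarbonyl would serve as well. They also leave open how the single mirror-image form compares with its counterpart on either arrangement.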